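The compounds below may be only part of what the source reports. "The series", "measured", "known", "first", "only" and "open" are said of these compounds alone.

Measured so far in a functional assay on HCT-116 cells (Homo sapiens) for inhibition, read by colorimetric assay, with a stated time of 3 days; a lower number here means a stronger inhibitor, a higher number a weaker inhibitor:

Compound 1, `O=C(CCCCCCNC(=O)C(O)(O)C(F)(F)F)Nc1ccccc1Br`: 14500 nM
Compound 2, `O=C(CCCCCCNC(=O)C(O)(O)C(F)(F)F)Nc1ccc(S(F)(F)(F)(F)F)cc1`: 9110 nM

Compound 2 has the lowest of the two numbers in this assay, and compound 1 sits within the scatter of it, so the two cannot be placed in order. Going by the values given here, with no second compound differing from compound 2 in a single place, nothing beyond these two values can be said of how the substituent on the aromatic ring of the shared core affects the number.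

Compound 3, `O=C(CCCCCCNC(=O)C(O)(O)C(F)(F)F)Nc1ccc(F)cc1`, is the next compound, still unmeasured in this assay. Compared with compound 2 it shows this difference: one fluorine atom in place of a group of 6 heavy atoms (5 fluorine, 1 sulfur; no ring), on an aromatic carbon. Both measured compounds give numbers in the same region despite different substituents on that ring, so no large step is expected. The step is expected to be about a 1.6-fold higher number from compound 2 to compound 3 (0.22 log units; within the scatter). Compound 3 is estimated at 15000 nM, within a range of 6000 nM to 40000 nM.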

Compound 3, half-maximal inhibitory concentration: 7570 nM
Compound 3: middle estimate off by 2.0-fold (0.30 log units), on the high side; the range from low to high includes it.
By their numbers in this assay, from the lowest: compounds 3, 2 and 1 (each within the scatter of the next).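

In this assay, one fluorine atom in place of the group of 6 heavy atoms (5 fluorine, 1 sulfur) on this aromatic carbon gives a 1.2-fold lower number from compound 2 to compound 3 (0.08 log units; within the scatter), so the two substituents, despite their difference in heavy atoms, cannot be told apart here. 4-Fluorophenyl in place of 2-bromophenyl on the amide-type nitrogen gives a 1.9-fold lower number from compound 1 to compound 3 (0.28 log units; within the scatter), which also lies within the scatter, so all three compounds sit at one level with no order among them. No measurement at hand offers an explanation for this result.

On these data alone, what an amine or a carboxylic acid on this aromatic carbon would give remains open. So does whether a longer chain in the shared core would move the number beyond the scatter.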